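The compounds below may be only part of what the source reports. "The series", "measured", "known", "first", "only" and "open" are said of these compounds alone.

Measured so far:
- compound 1 `O=C(NCCCCc1ccccc1)n1c(=O)oc2ccccc21`: 64 nM
- compound 2 `O=C(c1ccccc1)c1ccc2c(c1)oc(=O)n2C(=O)NCCCCc1ccccc1`: 29 nM

Within the data shown here, in an assay on HEK293 cells for inhibition of acid ceramidase (Homo sapiens), with a stated time of 10 min (a lower number here means a stronger inhibitor, a higher number a weaker inhibitor), compound 1 gives 64 nM, the higher of the two numbers so far. Compound 2 carries benzoyl in place of hydrogen on an aromatic carbon and gives 29 nM; the step is a 2.2-fold lower number from compound 1 to compound 2 (0.34 log units; beyond the scatter), a modest gain.

Compound 3 `O=C(NCCCCc1ccccc1)n1c(=O)oc2ccc(F)cc21` differs from compound 1 by fluoro in place of hydrogen on an aromatic carbon. Among the measured compounds shown here, no measured step exchanges hydrogen for fluoro, so the only step that bears on it is a 2.2-fold lower number from compound 1 to compound 2 (0.34 log units; beyond the scatter), and only loosely: benzoyl is a much larger group than fluoro, and it enters at a different aromatic carbon of the same core. That step shows that substitution on the core is tolerated and may help modestly, but it gives no direct guide for fluoro. A small step is therefore expected, most likely within the scatter, with direction uncertain.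

The number for compound 3 in this assay is estimated at 55 nM (range 25 nM to 130 nM), an expected step of a 1.2-fold lower number from compound 1 to compound 3 (0.07 log units; within the scatter).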

Compound 3, half-maximal inhibitory concentration: 12 nM
Beside the measured number, compound 3's estimate is 4.6-fold (0.66 log units) above it, outside the stated range (below it).
By their numbers in this assay, from the lowest: compound 3; then compound 2; then compound 1.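

In this assay, fluoro in place of hydrogen on an aromatic carbon of the shared core gives a 5.3-fold lower number from compound 1 to compound 3 (0.73 log units; beyond the scatter), so a single added heavy atom at this place, meta to a fused ring and para to a fused ring, is enough for a step beyond the scatter. Until now the only substitution shown on the core was benzoyl at a different aromatic carbon, so a substituent need not be large to lower the number. Nothing in the data given accounts for this step.

On these data alone, whether the step is particular to fluoro or extends to other groups at this carbon, such as chloro, methoxy or nitrile, stays open. Also open, as far as these compounds go, is whether fluoro at the other aromatic carbons of the core, or fluoro combined with benzoyl, would lower the number further.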